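The source may report more compounds than this note shows. Statements on the series, on what has been measured and on what is new or still open speak of the compounds shown alone.

Of the compounds shown here, three sharing one core have been read in a functional assay on HT-29 cells (Homo sapiens) for inhibition, read by MTT assay, with a stated time of 48 h (on this read-out higher numbers stand for weaker inhibition and lower numbers for stronger inhibition), and none of them yields a number. Compound 1 (`COc1cc(-c2nnc(S)n2-c2ccc(N(C)C)cc2)cc(OC)c1OC`) reads > 60000 nM which is a limit of the assay. Compound 2 (`COc1cc(-c2nnc(SC)n2-c2ccc(N(C)C)cc2)cc(OC)c1OC`) reads > 60000 nM which is again a limit. Compound 3 (`COc1ccc(C(=O)CSc2nnc(-c3cc(OC)c(OC)c(OC)c3)n2-c2ccc(N(C)C)cc2)cc1O`) reads > 60000 nM which is also a limit. Compound 3 therefore stands level with the other two at the same limit (the limit of > 60000 nM in this assay, at which 3 of the 3 values shown sit).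

Compound 4 (`COc1ccc(NC(=O)CSc2nnc(-c3cc(OC)c(OC)c(OC)c3)n2-c2ccc(N(C)C)cc2)cc1`) differs from compound 3 in one place: (4-methoxyphenyl)amino in place of 3-hydroxy-4-methoxyphenyl on a carbonyl carbon. The measured steps bearing on this change are (a step that the two limits leave unreadable from compound 1 to compound 2) and (a step that the two limits leave unreadable from compound 1 to compound 3) and (a step that the two limits leave unreadable from compound 2 to compound 3). Each alters what hangs from the sulfur, but none has a size that can be read, so none offers a direction to carry over.

The expectation therefore starts from compound 3 at > 60000 nM which is a limit and not a number. Compound 4 is expected to stay weak in this assay and may well return only a limit. The estimated step is an at least 1.5-fold lower number from compound 3 to compound 4 (0.17 log units; that floor lies within the scatter) and it would point, if anywhere, toward stronger inhibition. Compound 4 is estimated at 40000 nM with an expected range from 6000 nM to 80000 nM in this assay.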

Compound 4, half-maximal inhibitory concentration: 51400 nM
For compound 4 the middle estimate is 1.3-fold (0.11 log units) below the measured one, and the stated range covers the measured number.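

In this assay compound 4 is the only one of the four compounds shown that gives a number (51400 nM), and (4-methoxyphenyl)amino in place of 3-hydroxy-4-methoxyphenyl on the carbonyl carbon gives the first step with a readable floor (an at least 1.1-fold lower number from compound 3 to compound 4 (0.06 log units; that floor lies within the scatter)). Read from the smaller sulfur substituents, (4-methoxyphenyl)carbamoyl on the saturated chain carbon bound to the sulfur (an at least 1.1-fold lower number from compound 2 to compound 4 (0.06 log units; that floor lies within the scatter)) and ((4-methoxyphenyl)carbamoyl)methyl on the sulfur (an at least 1.1-fold lower number from compound 1 to compound 4 (0.06 log units; that floor lies within the scatter)) give the same picture, so all three floors lie within the scatter and no real gain in inhibition is established. The earlier steps among compound 1, compound 2 and compound 3 cannot be read, and the other three compounds remain at a shared limit: the limit of > 60000 nM in this assay, at which 3 of the 4 values shown sit.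

The compounds shown leave open whether the reading of compound 4 goes with the carbamoyl link or with the absence of the hydroxy group, since the two change together in this one step. Also open, going by these compounds, is whether a carboxylic acid on the saturated chain carbon, or a longer chain on the sulfur, would give a step that clearly exceeds the scatter.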